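Cytotoxicity notes: from compound 3 to compound 4

A few compounds are considered here, and "the series" means these few. Any claim that something is new, unique, unknown or untested is made for them only; others in the source may bear on it.

Measured in a functional assay on HL-60 cells (Homo sapiens) for cytotoxicity, read by MTT assay, with a stated time of 48 h (on this read-out higher numbers stand for weaker inhibition and lower numbers for stronger inhibition), as follows:
- compound 1 `Fc1cccc(-c2nc(Nc3ccccc3)c3cc(F)ccc3n2)c1` gives 48300 nM
- compound 2 `Fc1ccc(Nc2nc(-c3cccc(F)c3)nc3ccc(F)cc23)cc1` gives > 50000 nM (a limit of the assay)
- compound 3 `Nc1ccccc1Nc1nc(-c2cccc(F)c2)nc2ccc(F)cc12` gives 41300 nM

Compound 3 stands within the scatter of compound 1 on these numbers. The change to compound 4 `Cc1cccc(Nc2nc(-c3cccc(F)c3)nc3ccc(F)cc23)c1` is 3-methylphenyl in place of 2-aminophenyl on a nitrogen on an aromatic ring and puts 3-methylphenyl in place of 2-aminophenyl on a nitrogen on an aromatic ring. The closest measured swap on that nitrogen is an at least 1.2-fold lower number from compound 2 to compound 3 (0.08 log units; that floor lies within the scatter) and stays within the scatter, as do a 1.2-fold lower number from compound 1 to compound 3 (0.07 log units; within the scatter) and an at least 1.0-fold higher number from compound 1 to compound 2 (0.01 log units; that floor lies within the scatter) in this set. The steps touching compound 2 rest on the limit of > 50000 nM in this assay, at which 1 of the 3 values shown sits, and are floors only. No step beyond the scatter is therefore expected in this assay and a result reported only as a limit remains possible. The expected step is a 1.1-fold higher number from compound 3 to compound 4 (0.04 log units; within the scatter) and no larger. For compound 4 the estimated value is 45000 nM with an expected range from 22000 nM to 80000 nM in this measurement.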

Compound 4, half-maximal inhibitory concentration: > 50000 nM
Compound 4 was reported as a limit; the forecaster's own chance of this, stated with the estimate: 40%; middle value at least 1.1-fold (0.04 log units) away from the limit.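

In this assay, 3-methylphenyl in place of 2-aminophenyl on the nitrogen gives an at least 1.2-fold higher number from compound 3 to compound 4 (0.08 log units; that floor lies within the scatter), and adding a methyl group to the ring on that nitrogen gives an at least 1.0-fold higher number from compound 1 to compound 4 (0.01 log units; that floor lies within the scatter), so a methyl group on this ring brings no step beyond the scatter. Compound 4 is reported only as a limit. These two steps are therefore floors, and the step between compound 2 and compound 4 cannot be read: the limit of > 50000 nM in this assay, at which 2 of the 4 values shown sit.

As far as these compounds go, the true size of the steps ending at a limit stays open. Also open, from the compounds shown here alone, is whether a carboxylic acid or a longer chain on that nitrogen would give a step beyond the scatter.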